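This account rests on a few compounds, and the source may have more. Where it says the series, first, only, none or still open, it means among the compounds named here.

Measured so far:
- compound 1 `CCC1C(=O)N(C)c2cnc(-n3ccnc3-c3ccc(F)cc3)nc2N1c1ccc(F)cc1`: 15 nM
- compound 2 `CC[C@@H]1C(=O)N(C)c2cnc(-c3cn[nH]c3-c3nccs3)nc2N1[C@H]1CCOC1`: 39 nM

In an assay on isolated protein for inhibition of serine/threonine-protein kinase PLK2 (Homo sapiens), read by TR-FRET, with a stated time of 60 min (a lower number here means a stronger inhibitor, a higher number a weaker inhibitor), compound 1 gives the lower of the two numbers; compound 2 sits above it, and the gap between the two is beyond the usual scatter. Going by the values given here, no pair of measured compounds differs in one place, so no step of known size guides the next change.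

Compound 3 `CCC1C(=O)N(C)c2cnc(-n3ccnc3-c3ccc(F)cc3)nc2N1c1ccc(C#N)cc1` is compound 1 with cyano in place of fluoro on an aromatic carbon. Among the compounds with values here, with no comparable measured step, the expectation for compound 3 is a step of a 1.3-fold higher number from compound 1 to compound 3 (0.12 log units; within the scatter), likely within the scatter in either direction. Compound 3 is thus estimated at 20 nM in this assay, with a range from 6 nM to 65 nM.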

Compound 3, half-maximal inhibitory concentration: 31 nM
Compound 3: the middle estimate sits 1.6-fold (0.19 log units) below what was measured, and the stated range covers the measured number.
By their numbers in this assay, from the lowest: compound 1; then compounds 3 and 2 (each within the scatter of the next).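

In this assay, going by these compounds alone, going from 4-fluorophenyl to 4-cyanophenyl gives a 2.1-fold higher number from compound 1 to compound 3 (0.32 log units; beyond the scatter), the first step of known size. This position on the six-membered aromatic ring therefore responds to the change from fluoro to cyano, but the loss is only modest, and the nitrile is tolerated there. No available evidence bears on the origin of this step.

From the compounds shown here alone, whether a smaller group such as chloro or a hydrogen-bond-donating amine at the same place would match compound 1 remains open. So does whether methoxy would bring any gain.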